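A few compounds are considered here, and "the series" means these few. Any claim that something is new, unique, unknown or untested is made for them only; others in the source may bear on it.

Four compounds share one core: compound 1 `Oc1ccc(-c2cc(-c3ccsc3)cc(-c3ccc(O)cc3)n2)cc1`, compound 2 `Oc1ccc(-c2cc(-c3ccco3)cc(-c3ccc(O)cc3)n2)cc1`, compound 3 `Oc1ccc(-c2cc(-c3ccccn3)cc(-c3cccc(O)c3)n2)cc1` and the not yet measured compound 4 `Oc1ccc(-c2cc(-c3ccccn3)cc(-c3ccc(O)cc3)n2)cc1`. In a functional assay on HeLa cells (Homo sapiens) for cytotoxicity, read by CCK-8 assay (on this read-out lower numbers stand for stronger inhibition and higher numbers for weaker inhibition), compound 1 gives 4370 nM. Compound 2 reaches only a limit of this assay, > 50000 nM. Compound 3 gives 1930 nM, the lowest of the two numbers shown, with compound 1 as its nearest neighbour. The remaining value, that of compound 2, is a limit. Within the data shown here, the single step measured between these compounds is an at least 11-fold higher number from compound 1 to compound 2 (1.05 log units; beyond the scatter). That step ends at the limit of > 50000 nM in this assay, at which 1 of the 3 values shown sits, so its true size is not known.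

Compound 4 differs from compound 3 by 4-hydroxyphenyl in place of 3-hydroxyphenyl on an aromatic carbon. Among the measured compounds shown here, no measured step bears on this exchange: the one step measured concerns a different group on the core. Compound 4 is therefore expected to show no step beyond the scatter, and the estimated step of a 1.3-fold higher number from compound 3 to compound 4 (0.11 log units; within the scatter) stays within it. Compound 4 is expected to give about 2500 nM in this assay, between 900 nM and 7000 nM.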

Compound 4, half-maximal inhibitory concentration: > 50000 nM
Compound 4 was reported as a limit; the forecaster's own chance of this, stated with the estimate: 5%; middle value at least 20-fold (1.30 log units) from the limit.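

In this assay, the exchange of 3-hydroxyphenyl for 4-hydroxyphenyl, with the same atoms on the same aromatic carbon, gives an at least 25-fold higher number from compound 3 to compound 4 (1.41 log units; beyond the scatter), so the place of the hydroxyl on this phenyl group decides much of the result for this pair. With 4-hydroxyphenyl kept, pyridin-2-yl in place of thiophen-3-yl gives an at least 11-fold higher number from compound 1 to compound 4 (1.05 log units; beyond the scatter), and the earlier drop seen with furan-2-yl is thus not confined to that one group. The value of compound 4 is a limit, as is that of compound 2, so the step between these two cannot be read and the true sizes of the other steps stay unknown: the limit of > 50000 nM in this assay, at which 2 of the 4 values shown sit.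

The compounds shown leave open whether 3-hydroxyphenyl has the same effect when thiophen-3-yl or furan-2-yl sits on the core. They also leave open whether an amine or a methoxy group could stand in place of this hydroxyl.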